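The source may hold more compounds than are shown below. What is called first, only, known or untested is meant among the compounds shown, and "the series" means these compounds.

Measured so far in a functional assay on the whole organism with Rattus norvegicus as the target; on this read-out lower numbers stand for an effect already at smaller amounts and higher numbers for an effect only at larger amounts of compound
- compound 1 `CCN(CCNC(=O)c1cc(Cl)c(N)cc1OC)Cc1ccccc1OC` gives 10 mg/kg
- compound 2 `CCN(CCNC(=O)c1cc(Cl)c(N)cc1OC)Cc1ccccc1Cl` gives 10 mg/kg

Compound 2 stands level with compound 1 at the digits shown, and no other measured compound is available to place it against. Among the compounds with values here, the only measured step is no change at the digits printed from compound 1 to compound 2 (within the scatter) and it puts chloro in place of methoxy on an aromatic carbon. Compound 3 `CCN(CCNC(=O)c1cc(Cl)c(N)cc1OC)Cc1ccc(Cl)cc1` has the same atoms as compound 2, joined differently: 4-chlorophenyl in place of 2-chlorophenyl on a saturated chain carbon bound to an amine nitrogen and this is 4-chlorophenyl in place of 2-chlorophenyl on a saturated chain carbon bound to an amine nitrogen. Within the data shown here, no measured step shows this kind of change, so the evidence is indirect. Among the measured compounds shown here, the expectation rests on compound 2 at 10 mg/kg and on the single step of no change at the digits printed from compound 1 to compound 2 (within the scatter) as the only guide to size. The estimated step is no change at the digits printed from compound 2 to compound 3 (within the scatter) with no favoured direction and nothing expected beyond the scatter. Compound 3 is expected at 10 mg/kg with an estimated range from 3 mg/kg to 30 mg/kg in this wide form because so little has been measured.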

Compound 3, dose for half-maximal effect: 0.24 mg/kg
Estimate against measurement, compound 3: 42-fold (1.62 log units) above, outside the stated range (below it).
By their numbers in this assay, from the lowest: compound 3; then compounds 1 and 2 (each within the scatter of the next).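

In this assay, where the chlorine sits on the aromatic ring matters: with the same atoms joined differently, the change gives a 42-fold lower number from compound 2 to compound 3 (1.62 log units; beyond the scatter) and so stands apart from the exchange of methoxy for chloro, which gave no change at the digits printed from compound 1 to compound 2 (within the scatter) as its step. The 4-chlorophenyl group also stands clear of the 2-methoxyphenyl group, with a 42-fold lower number from compound 1 to compound 3 (1.62 log units; beyond the scatter) on the saturated chain carbon bound to an amine nitrogen, so among these three compounds the location of the substituent counts for more than the one exchange of substituent shown. No measurement on these compounds accounts for this difference.

An unsubstituted phenyl at this place would show whether the 4-chlorophenyl group improves on the bare ring or the 2-substituted groups fall short of it. Going by these compounds, it also remains open whether bromo or methyl can replace the chlorine of the 4-chlorophenyl group and keep the value.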